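A few compounds are considered here, and "the series" means these few. Any claim that something is new, unique, unknown or untested is made for them only; others in the source may bear on it.

Going by the values given here, compound 2, with the structure `CC[C@@]1(CCCc2ccccc2)C(=O)N(c2c(OC)cc(OC)cc2OC)[C@@H]1c1ccccc1`, stands at the top of the two numbers measured so far: in an assay for inhibition of sterol O-acyltransferase 1 (Rattus norvegicus), using microsomes, tested at 10 uM (on this read-out lower numbers stand for less inhibition and higher numbers for more inhibition at the one concentration tested (going by the name of the read-out)), compound 2 gives 82%. Among the compounds with values here, its only measured neighbour is compound 1, drawn as `CC[C@]1(CCCc2ccccc2)C(=O)N(c2c(OC)cc(OC)cc2OC)[C@@H]1c1ccccc1`, which in this assay gives 42%. The two share every atom and bond, so the step of a number 40 percentage points higher from compound 1 to compound 2 (beyond the scatter) rests on nothing but the drawn configuration at one saturated ring carbon, and that is why it says so much: because of the fact that compounds 1 and 2 differ only in the configuration as drawn, the arrangement of the groups around the small ring decides whether inhibition is modest or strong.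

Compound 3, with the structure `CC[C@]1(CCCc2ccccc2)CN(c2c(OC)cc(OC)cc2OC)C1=O`, is not yet measured. It differs from compound 2 in one place: hydrogen in place of phenyl on a saturated ring carbon. Removing the phenyl takes away one of the groups whose relative arrangement the step from compound 1 to compound 2 showed to matter so strongly, so in this assay a drop beyond the scatter is expected, of the order of a number 47 percentage points lower from compound 2 to compound 3 (beyond the scatter). Compound 3 is therefore estimated to give about 35%, most likely between 5% and 70%.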

Compound 3, a percentage reported as inhibition, at one concentration (the size of the read-out at that concentration, not a potency): 38%
The estimate for compound 3 lay 3 percentage points below the measured number; measured number inside the range.
By their numbers in this assay, from the lowest: compounds 3 and 1 (each within the scatter of the next); then compound 2.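

Compounds 1 and 2 could speak only of how the groups are arranged, for one reason: the fact that compounds 1 and 2 differ only in the configuration as drawn. The new step concerns the group itself: with hydrogen in place of phenyl on the saturated ring carbon next to the ring nitrogen, there is a number 44 percentage points lower from compound 2 to compound 3 (beyond the scatter) in this assay, so the strong inhibition of compound 2 depends on having the phenyl at this position, not only on how it is arranged. The phenyl does not account for all of the inhibition, however, since without it compound 3 still gives 38%, so inhibition at this one concentration does not vanish.

The compounds shown leave open whether this carbon needs an aromatic ring in particular or whether other groups, such as a methyl, a cyclohexyl or a benzyl group, would restore the inhibition. They also leave open how far the compounds differ in potency, as a single reading at one concentration does not give a potency.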